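A Chlorine Added to the Benzyl Arm

The source may report more compounds than this note shows. Statements on the series, on what has been measured and on what is new or still open speak of the compounds shown alone.

Measured so far:
compound 1 `CC1=C(C(=O)Nc2ccc(Br)cc2)C(c2ccc(Cl)cc2Cl)N=C(SCc2ccccc2)N1`: 10.3%
compound 2 `CC1=C(C(=O)Nc2ccc(Br)cc2)C(c2ccc(Cl)cc2Cl)N=C(SCc2ccccc2Cl)N1`: 16%
compound 3 `COc1ccc(C2N=C(SCc3ccccc3)NC(C)=C2C(=O)Nc2ccc(Br)cc2)cc1`: 8.2%

In a functional assay on the whole organism (artery, strain albino) with Rattus norvegicus as the target, with a stated time of 120 min, at a dose of 10 mg/kg by the oral route (a higher number here means more inhibition at the dose given (going by the name of the read-out), a lower number less inhibition), compound 3 gives 8.2%, which sits at the low end of the three numbers; its gaps to compound 1 and compound 2 both lie within the scatter, so no real difference among the three can be claimed. Compound 4 `COc1ccc(C2N=C(SCc3ccccc3Cl)NC(C)=C2C(=O)Nc2ccc(Br)cc2)cc1` differs from compound 3 by one change: chloro in place of hydrogen on an aromatic carbon. Within the data shown here, the only measured step of the same kind is a number 5.7 percentage points higher from compound 1 to compound 2 (within the scatter), a shift that stayed within the scatter. On that single precedent, compound 4 is expected to move by a number 4.8 percentage points higher from compound 3 to compound 4 (within the scatter), a small upward shift that may well vanish in repeat measurements. Compound 4 is therefore estimated at 13%, with a range from 3% to 23%.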

Compound 4, a percentage reported as inhibition, in the whole organism at one dose (the size of the read-out at that dose, not a potency): 8.2%
Estimate against measurement, compound 4: 4.8 percentage points above, within the range that was stated.
By their numbers in this assay, from the lowest: compounds 3, 4, 1 and 2 (each within the scatter of the next).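

Going from benzyl to 2-chlorobenzyl on the core of compound 3 gives no change at the digits printed from compound 3 to compound 4 (within the scatter) in this assay, so a second core also shows no real effect of this chloro, and the two readings of the change agree: the same change on two cores in this assay, a number 5.7 percentage points higher (within the scatter) from compound 1 to compound 2 and no change at the digits printed (within the scatter) from compound 3 to compound 4, 5.7 percentage points apart, within the scatter of two such steps. Placing 4-methoxyphenyl in place of 2,4-dichlorophenyl with the chloro present gives a number 7.8 percentage points lower from compound 2 to compound 4 (within the scatter), and this change also reads alike with and without the chloro: the same change on two cores in this assay, a number 2.1 percentage points lower (within the scatter) from compound 1 to compound 3 and a number 7.8 percentage points lower (within the scatter) from compound 2 to compound 4, 5.7 percentage points apart, within the scatter of two such steps. All four compounds therefore remain within the scatter of their neighbours.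

Still open, as far as these compounds go, is whether an amine or a carboxylic acid on this aromatic ring, or a longer chain in place of benzyl, would give a step beyond the scatter.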